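The compounds below may be only part of what the source reports. "The series", "measured", "known", "first", "only" and "open" are said of these compounds alone.

Working notes on the series. Compound 1 `COc1cc(-c2cc(/C=C/C(=O)c3ccc(Cl)c(Cl)c3)[nH]n2)cc(OC)c1OC` and compound 2 `COc1ccc(C(=O)/C=C/c2cc(-c3cc(OC)c(OC)c(OC)c3)n[nH]2)cc1` share one core and differ only in the aryl group on the carbonyl carbon. In a functional assay on COLO 205 cells (Homo sapiens) for inhibition, read by sulforhodamine B assay, with a stated time of 48 h (on this read-out lower numbers stand for stronger inhibition of growth and higher numbers for weaker inhibition of growth), compound 1 gives 15800 nM, while compound 2 gives 3240 nM. For the measured compounds named here, the single measured step is a 4.9-fold lower number from compound 1 to compound 2 (0.69 log units; beyond the scatter). Going by the values given here, compound 2 therefore holds the lowest of the two numbers so far, with compound 1 as its nearest neighbour.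

Compound 3 `COc1cc(-c2cc(/C=C/C(=O)c3ccc(F)c(F)c3)[nH]n2)cc(OC)c1OC` differs from compound 2 in one place: 3,4-difluorophenyl in place of 4-methoxyphenyl on a carbonyl carbon. Among the compounds with values here, the only measured step that bears on this exchange is a 4.9-fold lower number from compound 1 to compound 2 (0.69 log units; beyond the scatter), in which the 3,4-dichlorophenyl group at the same carbonyl carbon was replaced by the 4-methoxyphenyl group. Within the data shown here, compound 3 moves back from the 4-methoxyphenyl group to a 3,4-dihalogenated ring, now the 3,4-difluorophenyl group, so in this assay a step in the reverse direction is expected, toward a higher number than that of compound 2, and plausibly of similar size to the measured step, since no fluorine analogue has been measured to refine it. The expected step is a 2.8-fold higher number from compound 2 to compound 3 (0.44 log units; beyond the scatter). Compound 3 is estimated at 9000 nM, with a range from 3500 nM to 25000 nM.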

Compound 3, concentration for total growth inhibition: 3190 nM
Compound 3: the middle estimate sits 2.8-fold (0.45 log units) above what was measured; measured number outside the range, below it.
By their numbers in this assay, from the lowest: compounds 3 and 2 (each within the scatter of the next); then compound 1.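

In this assay the carbonyl carbon does not separate the 3,4-difluorophenyl group from the 4-methoxyphenyl group, with a 1.0-fold lower number from compound 2 to compound 3 (0.01 log units; within the scatter). The change from 3,4-dichlorophenyl to 3,4-difluorophenyl gives a 5.0-fold lower number from compound 1 to compound 3 (0.69 log units; beyond the scatter), so a step of this size now appears between two 3,4-dihalogenated rings as well as between the 3,4-dichlorophenyl and 4-methoxyphenyl groups. Among these three compounds, compound 1 alone stands apart from the others, and compound 3 goes against any reading that the 4-methoxyphenyl group is needed for the lower number or that a 3,4-dihalogenated ring in general gives the higher one. No measurement at hand gives an explanation for these steps.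

The compounds shown leave open how an unsubstituted phenyl ring, a ring with a single chlorine or a single fluorine, or a ring carrying an amine or a carboxylic acid would read at this carbonyl carbon. They also leave open whether the match between compound 2 and compound 3 would hold on the other side of the shared core, where every compound here keeps the same trimethoxyphenyl group.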